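The compounds below may be only part of what the source reports. "The series", "measured", "known", "first", "only" and "open" are said of these compounds alone.

Compounds measured:
- compound 1, `CC(C)N1CCc2nc(C#Cc3cccnc3)ccc2C1=O`: "not active" (no number reported)
- compound 2, `O=C1c2ccc(C#Cc3ccccc3)nc2CCN1C1CCCC1`: 5.9 nM
- compound 3, `Cc1cccc(C#Cc2ccc3c(n2)CCN(C2CCCC2)C3=O)c1`: 7.5 nM

In a functional assay on HEK293 cells for positive allosteric modulation of metabotropic glutamate receptor 5 (Homo sapiens), read by FLIPR and calcium flux (a lower number here means that less compound is needed, a higher number that more compound is needed for the effect), compound 1 is reported as "not active" (no number reported), so no number stands for it and its place on the scale cannot be given. Compound 4, `O=C1c2ccc(C#Cc3cccnc3)nc2CCN1C1CCCC1`, differs from compound 1 by cyclopentyl in place of isopropyl on an amide-type nitrogen in a ring. Among the compounds with values here, the only measured step, a 1.3-fold higher number from compound 2 to compound 3 (0.10 log units; within the scatter), concerns a methyl on an aromatic carbon and does not bear on this change. Within the data shown here, what remains is that compound 2 and compound 3, which both carry the cyclopentyl group on that nitrogen, are active with numbers close together, while they differ from compound 4 elsewhere in the structure, so no step is known for the change itself. From that, compound 4 is expected to give a number in this assay rather than no activity, though with wide uncertainty, and its estimate is 60 nM with a range from 8 nM to 600 nM.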

Compound 4, half-maximal effective concentration: 748 nM
Compound 4: the middle estimate sits 12-fold (1.10 log units) below what was measured; measured number outside the range, above it.
By their numbers in this assay, from the lowest: compounds 2 and 3 (each within the scatter of the next); then compound 4.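

With cyclopentyl held on the amide-type nitrogen, the group on the triple-bonded carbon proves decisive in this assay: pyridin-3-yl in place of phenyl gives a 130-fold higher number from compound 2 to compound 4 (2.10 log units; beyond the scatter) and pyridin-3-yl in place of 3-methylphenyl gives a 100-fold higher number from compound 3 to compound 4 (2.00 log units; beyond the scatter) while the earlier methyl step stayed within the scatter. With pyridin-3-yl on that carbon, the group on the nitrogen also matters, since compound 1 with isopropyl is "not active" (no number reported) and compound 4 with cyclopentyl gives 748 nM as a measurable number. No evidence at hand accounts for either difference.

The compounds shown leave open whether isopropyl on that nitrogen would still give a number with phenyl on the triple-bonded carbon. They also leave open how pyridin-2-yl or 3-fluorophenyl on that carbon, or cyclohexyl on the nitrogen, would stand.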